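Carboxy in place of hydroxy on compound 2

A few compounds are considered here, and "the series" means these few. Any claim that something is new, unique, unknown or untested is made for them only; others in the source may bear on it.

Compound 1 `COc1ccc(-c2nc3cnccc3n2-c2cc(OC)c(OC)c(OC)c2)cc1O` gives > 20000 nM in a functional assay on A549 cells (Homo sapiens) for antiproliferative activity, read by MTT assay, with a stated time of 48 h (a higher number here means a weaker inhibitor, a lower number a stronger inhibitor), as a limit of the assay, not a number. Within the data shown here, compound 2 `COc1ccc(-c2cc3c(cn2)[nH]c(=O)n3-c2cc(OC)c(OC)c(OC)c2)cc1O` gives 630 nM as the only actual number so far. Compound 3 `COc1ccc(-c2cc3c(cn2)[nH]c(=O)n3-c2cc(OC)c(OC)c(OC)c2)cc1C(=O)O` carries carboxy in place of hydroxy on an aromatic carbon, ortho to a methoxy group. The change carboxy in place of hydroxy on an aromatic carbon turns 3-hydroxy-4-methoxyphenyl into 3-carboxy-4-methoxyphenyl. Among the measured compounds shown here, with no measured step to go by, a weakening beyond the scatter is expected in this assay on the structural change alone. The expected move is a 9.5-fold higher number from compound 2 to compound 3 (0.98 log units; beyond the scatter) toward weaker inhibition. Compound 3 is estimated at 6000 nM with an expected range of 1500 nM to 20000 nM in this assay.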

Compound 3, half-maximal inhibitory concentration: 1280 nM
The estimate for compound 3 lay 4.7-fold (0.67 log units) above the measured number; measured number below the stated range.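

In this assay, carboxy in place of hydroxy on the aromatic carbon ortho to a methoxy group gives a 2.0-fold higher number from compound 2 to compound 3 (0.31 log units; beyond the scatter), a modest weakening. This is the first single change shown at this position: the hydroxy is not essential for a measurable value, and the larger carboxy group is accepted there at a modest cost. Nothing shown bears on the reason for this step. Still open, as far as these compounds go, is how a methyl ester, a primary amide or an amine at this position would compare with compound 3.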